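The source may report more compounds than this note shows. Statements on the series, on what has been measured and on what is new or still open speak of the compounds shown alone.

Measured so far in a functional assay on Jurkat cells (Homo sapiens) for activation, with a stated time of 24 h; a lower number here means that less compound is needed, a higher number that more compound is needed for the effect:
- compound 1, `Oc1ccccc1CNc1ccc(-c2ccccc2)cc1`: 1820 nM
- compound 2, `CC(C)(C)c1ccc(-c2ccc(NCc3ccccc3O)cc2)cc1`: "not active" (no number reported)
- compound 3, `Oc1ccc(-c2ccc(NCc3ccccc3O)cc2)cc1`: "not active" (no number reported)

Within the data shown here, compound 1 carries the only number in this assay; compound 2 and compound 3 come back without a number, each reported as not active. Among the measured compounds shown here, no pair among the measured compounds differs in a single place, so no measured step is available.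

Compound 4, `COc1cccc(-c2ccc(NCc3ccccc3O)cc2)c1`, differs from compound 1 by methoxy in place of hydrogen on an aromatic carbon. The two entries without a number show that adding a group on the same ring of the shared core can remove measurable activity, so a step in the weaker direction, beyond the scatter, is expected, with a real chance that no number is returned at all. Compound 4 is therefore estimated at 4500 nM (range 1500 nM to 15000 nM), a step of a 2.5-fold higher number from compound 1 to compound 4 (0.39 log units; beyond the scatter).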

Compound 4, half-maximal effective concentration: "not active" (no number reported)
Compound 4 has no reported number here; the estimate stays without a comparison.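

In this assay, among these compounds, compound 4 returns no number, so no step from compound 1 can be read. The compounds shown leave open whether any added group on that ring keeps a measurable number. No available evidence bears on this result.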